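Aryl ketone swap at the carbonyl carbon: compound 4

The compounds below may be only part of what the source reports. "The series", "measured", "known", "first", "only" and "open" are said of these compounds alone.

Measured compounds:
Compound 1, `COc1cc(-c2nnc3n2NC(c2ccco2)C(C(=O)c2ccccc2F)S3)cc(OC)c1OC`, gives 94800 nM in a functional assay on MCF7 cells (Homo sapiens) for cytotoxicity, read by MTT assay, with a stated time of 48 h; on this read-out higher numbers stand for weaker inhibition and lower numbers for stronger inhibition.
Compound 2, `COc1cc(-c2nnc3n2NC(c2ccco2)C(C(=O)c2cccs2)S3)cc(OC)c1OC`, is recorded only as a limit, > 100000 nM, in this assay.
Compound 3, `COc1cc(-c2nnc3n2NC(c2ccco2)C(C(=O)c2ccc(F)c(F)c2)S3)cc(OC)c1OC`, gives 73200 nM in this assay.

Compound 2 thus stands at a limit of this assay rather than at a number, (the limit of > 100000 nM in this assay, at which 1 of the 3 values shown sits). The two measured steps that touch it are small: an at least 1.0-fold higher number from compound 1 to compound 2 (0.02 log units; that floor lies within the scatter) and an at least 1.3-fold lower number from compound 2 to compound 3 (0.13 log units; that floor lies within the scatter). The remaining step between measured compounds, a 1.3-fold lower number from compound 1 to compound 3 (0.11 log units; within the scatter), is also within the scatter, so the three aryl ketones so far give no separation beyond it.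

Compound 4, `COc1cc(-c2nnc3n2NC(c2ccco2)C(C(=O)c2ccc([N+](=O)[O-])cc2)S3)cc(OC)c1OC`, differs from compound 2 in one place: 4-nitrophenyl in place of thiophen-2-yl on a carbonyl carbon. Among the compounds with values here, no measured step involves 4-nitrophenyl, so the change itself carries no precedent. Within the data shown here, what bears on it is only that both recorded steps away from compound 2 sit within the scatter, which points to no step beyond the scatter for this change either. The step expected for compound 4 is an at least 1.1-fold lower number from compound 2 to compound 4 (0.04 log units; that floor lies within the scatter). Compound 4 is therefore estimated at 90000 nM, with a range from 40000 nM to 200000 nM, and a result that is again only a limit remains quite possible.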

Compound 4, half-maximal inhibitory concentration: > 100000 nM
Compound 4: no number, only a limit; the forecaster's own chance of this, stated with the estimate: 40%; middle value at least 1.1-fold (0.04 log units) away from the limit.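

Compound 4 is recorded only as a limit, > 100000 nM in this assay, so 4-nitrophenyl becomes the second group on this carbonyl carbon to give a limit rather than a number: the limit of > 100000 nM in this assay, at which 2 of the 4 values shown sit. The step between compound 2 and compound 4 cannot be read with both values at the limit, and the two readable steps are floors only: an at least 1.3-fold higher number from compound 3 to compound 4 (0.13 log units; that floor lies within the scatter) and an at least 1.0-fold higher number from compound 1 to compound 4 (0.02 log units; that floor lies within the scatter). A six-membered aromatic ring of carbon only with a nitro group, at 9 heavy atoms, therefore adds no separation beyond the scatter to what the 2-fluorophenyl, 3,4-difluorophenyl and thiophen-2-yl ketones already showed, although the floors do not fix how far compound 4 actually lies from compound 1 or compound 3.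

Still open, going by these compounds, is whether any group at this place, such as an aromatic ring carrying an amine or a carboxylic acid, gives a step beyond the scatter in this assay. The four compounds shown differ only on this carbonyl carbon, which leaves the contribution of the rest of the shared core unaddressed.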